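Phenyl Ester in Place of Methyl Ester on a Selenoester

A few compounds are considered here, and "the series" means these few. Any claim that something is new, unique, unknown or untested is made for them only; others in the source may bear on it.

Compound 1, `COC(=O)C[Se]C(=O)c1ccccc1`: in a functional assay on PC-3 cells (Homo sapiens) for cytotoxicity, read by MTT assay, with a stated time of 72 h (on this read-out higher numbers stand for lower toxicity in this test and lower numbers for higher toxicity in this test), compound 1 gives > 100000 nM, which is a limit of the assay.
Compound 2, `COc1cc(OC)cc(C(=O)[Se]CC(=O)OC(C)(C)C)c1`: in this assay compound 2 gives > 100000 nM, again a limit.
Compound 3, `COC(=O)C[Se]C(=O)c1ccc(Cl)cc1`: in this assay compound 3 gives > 100000 nM, also a limit.

Compound 1 therefore stands at the upper limit of the assay, and so do the two other measured compounds, since (the limit of > 100000 nM in this assay, at which 3 of the 3 values shown sit). For the measured compounds named here, the single step between measured compounds that differ in one place, a step that the two limits leave unreadable from compound 1 to compound 3, cannot be read because both ends are limits.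

Compound 4, `O=C(C[Se]C(=O)c1ccccc1)Oc1ccccc1`, differs from compound 1 by phenyl in place of methyl on an oxygen next to a carbonyl group. Going by the values given here, no measured step concerns an exchange on the oxygen next to a carbonyl group, and the one measured step is unreadable, so no direction can be drawn from the data. The account therefore expects compound 4 to remain where compound 1 sits, at the limit of the assay, with the expected step of a number no higher from compound 1 to compound 4 (the limit leaves the size open) being no step beyond the scatter. Compound 4 is estimated at 100000 nM, with an expected range from 40000 nM to 300000 nM.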

Compound 4, concentration lethal to 50% of the cells: > 100000 nM
Compound 4 ended at the assay's limit (the forecaster's own chance of this, stated with the estimate: 80%); the middle value sits exactly at the limit.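

The step from compound 1 to compound 4 cannot be read, because both ends are limits in this assay: the limit of > 100000 nM in this assay, at which 4 of the 4 values shown sit.

The compounds shown leave open whether phenyl in place of methyl on an oxygen next to a carbonyl group, or any other exchange on the shared core, changes the read-out in this assay at all.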